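The compounds below may be only part of what the source reports. "The series", "measured", "known", "first", "only" and "open" are said of these compounds alone.

In a functional assay on RAW264.7 cells (Mus musculus) for cytotoxicity, read by MTT assay, with a stated time of 48 h (a higher number here means a weaker inhibitor, a lower number a stronger inhibitor), compound 1 `CS(=O)(=O)c1ccc(Cc2nnc3n2N=C(c2ccccc2)CS3)cc1` gives 25000 nM. Compound 2 `CS(=O)(=O)c1ccc(Cc2nnc3n2N=C(c2ccc(Cl)cc2Cl)CS3)cc1` gives > 100000 nM, which is a limit and not a number. Going by these compounds, compound 3 `Cc1ccc(C2=Nn3c(Cc4ccc(S(C)(=O)=O)cc4)nnc3SC2)cc1` gives > 100000 nM, again only a limit, so its exact place on the scale is unknown.

Compound 4 `CS(=O)(=O)c1ccc(Cc2nnc3n2N=C(c2ccc(O)c(C(N)=O)c2)CS3)cc1` changes one group on the carbon with a double bond to nitrogen: 3-carbamoyl-4-hydroxyphenyl in place of 4-methylphenyl on a carbon with a double bond to nitrogen. Going by the values given here, two measured steps bear on this change, and both start from the plain phenyl of compound 1. They are an at least 4.0-fold higher number from compound 1 to compound 2 (0.60 log units; beyond the scatter) and an at least 4.0-fold higher number from compound 1 to compound 3 (0.60 log units; beyond the scatter). The step between the two limits cannot be read, and neither step involves the group that enters here, so they are only a rough guide.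

Compound 4 also carries a substituted phenyl, so the number is expected to stay high, and no clear step from the limit is expected. Compound 4 is estimated at 70000 nM, with an expected range of 20000 nM to 200000 nM. The estimate means an at least 1.4-fold lower number from compound 3 to compound 4 (0.15 log units; that floor lies within the scatter).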

Compound 4, half-maximal inhibitory concentration: > 100000 nM
Compound 4: a limit, no number (the forecaster's own chance of this, stated with the estimate: 55%); middle value at least 1.4-fold (0.15 log units) from the limit.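

At this position, on the carbon with a double bond to nitrogen, the swap of phenyl for 3-carbamoyl-4-hydroxyphenyl gives an at least 4.0-fold higher number from compound 1 to compound 4 (0.60 log units; beyond the scatter) in this assay. So a phenyl carrying hydrogen-bond donors and acceptors ends up in the same place as the 4-methylphenyl and 2,4-dichlorophenyl of compound 3 and compound 2, and among these four compounds only the plain phenyl of compound 1 gives a measured number. Compound 4 gives only a limit, and steps among the three limits cannot be read: the limit of > 100000 nM in this assay, at which 3 of the 4 values shown sit.

Going by these compounds, how far the values of compound 2, compound 3 and compound 4 lie past that limit stays unknown. Also open, on these data alone, are what a lone hydroxyl or a lone carboxamide would do on the phenyl, and where a phenyl bearing an amine or a carboxylic acid, or an alkyl chain in place of the phenyl, would fall relative to compound 1.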